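Difluoromethyl in place of cyclopropyl: compound 2 to compound 3

The compounds below may be only part of what the source reports. "The series", "measured", "known", "first", "only" and "open" are said of these compounds alone.

Among the measured compounds shown here, in an in vitro ADME assay on microsomes from liver (Simiiformes) (a lower number here means that the compound disappears faster, a higher number that the compound lasts longer), compound 2 `Cc1cc(CCCOc2c(C)cc(-c3noc(C4CC4)n3)cc2C)on1` gives 2.23 h as the only actual number so far. Compound 1 `CCOc1nc(-c2cc(C)c(OCCCc3cc(C)no3)c(C)c2)no1` gives > 2.5 h and this is a limit of the assay, not a number. The unmeasured compound 3 `Cc1cc(CCCOc2c(C)cc(-c3noc(C(F)F)n3)cc2C)on1` carries difluoromethyl in place of cyclopropyl on an aromatic carbon and is otherwise unchanged. For the measured compounds named here, the one measured step at that carbon is an at least 1.1-fold lower number from compound 1 to compound 2 (0.04 log units; that floor lies within the scatter) and it brings cyclopropyl in place of ethoxy. On these data alone, its floor lies within the scatter, and its true size stays open given the limit of > 2.5 h in this assay, at which 1 of the 2 values shown sits, in these data. That step says nothing about difluoromethyl itself, so with compound 2 at 2.23 h no change beyond the scatter is expected in this assay for this swap. The expected move is a 1.1-fold lower number from compound 2 to compound 3 (0.05 log units; within the scatter) and lies within the scatter. Compound 3 is estimated at 2 h with a range from 1 h to 3.5 h for repeated measurements.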

Compound 3, half-life: 1.42 h
Compound 3: the middle estimate sits 1.4-fold (0.15 log units) above what was measured; the range from low to high includes it.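

In this assay, among the compounds shown here, the first step at this carbon that rests on two actual numbers is a 1.6-fold lower number from compound 2 to compound 3 (0.20 log units; within the scatter), so difluoromethyl and cyclopropyl on the five-membered aromatic ring cannot be told apart here. Against ethoxy, the reading is an at least 1.7-fold lower number from compound 1 to compound 3 (0.24 log units; that floor lies within the scatter), which is a floor rather than a size, so neither group is yet shown to differ from ethoxy beyond the scatter. Compound 1 is the one compound that stands at a limit of the assay rather than at a number: the limit of > 2.5 h in this assay, at which 1 of the 3 values shown sits.

The compounds shown leave open how far ethoxy truly lies from the other two groups. They also leave open how an amine, a trifluoromethyl or a longer chain on this same carbon would read in this assay.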